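The source may hold more compounds than are shown below. What is called first, only, known or untested is meant among the compounds shown, and "the series" means these compounds.

Measured compounds:
compound 1, `O=C(Nc1cccc(-n2cc(-c3ccncc3)c(-c3ccc(Cl)c(O)c3)n2)c1)Nc1cc(C(F)(F)F)cc(C(F)(F)F)c1`: 877 nM
compound 2, `COc1cc(-c2nn(-c3cccc(NC(=O)Nc4ccc(Cl)c(C(F)(F)F)c4)c3)cc2-c2ccncc2)ccc1Cl`: 1280 nM
compound 3, `COc1cc(-c2nn(-c3cccc(NC(=O)c4ccccc4)c3)cc2-c2ccncc2)ccc1Cl`: 575 nM

In a functional assay on SNB-75 cells (Homo sapiens) for inhibition, read by sulforhodamine B assay, with a stated time of 48 h (on this read-out lower numbers stand for stronger inhibition of growth and higher numbers for weaker inhibition of growth), compound 1 gives 877 nM. Compound 2 gives 1280 nM and compound 3 gives 575 nM. Compound 1 sits second highest of the three numbers; its gap to compound 2 and its gap to compound 3 both lie within the usual scatter, so the three cannot be ordered against one another with confidence from these values alone. Among the compounds with values here, the only single-place step recorded is a 2.2-fold lower number from compound 2 to compound 3 (0.35 log units; beyond the scatter).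

Compound 4, `O=C(Nc1cccc(-n2cc(-c3ccncc3)c(-c3ccc(Cl)c(O)c3)n2)c1)Nc1cccc(C(F)(F)F)c1`, is not yet measured. It differs from compound 1 by hydrogen in place of trifluoromethyl on an aromatic carbon. Within the data shown here, no measured pair shows this particular change: the step from compound 2 to compound 3 alters the urea end of the molecule far more broadly, and it sits on a different shared core. It therefore only tells that the aryl portion attached to the carbonyl tolerates considerable change without a large swing in this assay. On that basis no step beyond the scatter is expected for compound 4, in either direction, and the estimated step is a 1.3-fold higher number from compound 1 to compound 4 (0.10 log units; within the scatter). Compound 4 is expected to give about 1100 nM, within a range of 450 nM to 2700 nM.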

Compound 4, concentration for 50% growth inhibition: 3650 nM
Beside the measured number, compound 4's estimate is 3.3-fold (0.52 log units) below it; the whole stated range lies below it.
By their numbers in this assay, from the lowest: compounds 3, 1 and 2 (each within the scatter of the next, the first and the last beyond it); then compound 4.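

In this assay, hydrogen in place of trifluoromethyl on an aromatic carbon gives a 4.2-fold higher number from compound 1 to compound 4 (0.62 log units; beyond the scatter), so this one position on the aromatic ring of the urea end does register in the read-out, and the trifluoromethyl group left in compound 4 does not keep the number level with that of compound 1. The earlier step, a 2.2-fold lower number from compound 2 to compound 3 (0.35 log units; beyond the scatter), exchanged a much larger portion of that end on a different shared core and could not show what a single group at this position contributes; the new step shows that a change of 4 heavy atoms here can move the number beyond the scatter, and in the direction of weaker inhibition of growth. No measurement among these compounds gives a reason for this step.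

The compounds shown leave open whether another group at this position, such as a nitrile, a methyl group or an amine, would give a number closer to that of compound 1 or to that of compound 4. They also leave open whether the same exchange would give a step of similar size on the core of compound 2.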